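The source may report more compounds than this note shows. Statements on the series, on what has been measured and on what is new or still open speak of the compounds shown alone.

Working notes on the series. Compound 1 `N#Cc1ccc(-c2csc(N/N=C\c3ccco3)n2)cc1` and compound 3 `Fc1ccc(-c2csc(N/N=C\c3ccco3)n2)cc1` share one core, while compound 2 `C/C(=N/Nc1nc(-c2ccc(C#N)cc2)cs1)c1cccs1` is built on a different core; the difference between the two cores is not broken down here. In an in vitro assay on BTI-TN-5B1-4 cells for inhibition of Amine oxidase [flavin-containing] A (Homo sapiens), read by Amplex Red, with a stated time of 15 min, tested at 100 uM (on this read-out higher numbers stand for more inhibition at the one concentration tested (going by the name of the read-out) and lower numbers for less inhibition), compound 1 gives 40%, compound 3 gives 40% and compound 2 gives 40%, so compound 2 stands level with compounds 1 and 3 at the digits printed, all within the scatter of one another. The change from compound 1 to compound 3 is fluoro in place of cyano on an aromatic carbon, and the step it made, no change at the digits printed from compound 1 to compound 3 (within the scatter), lies within the scatter. Compound 4 `C/C(=N/Nc1nc(-c2ccc(F)cc2)cs1)c1cccs1` is not yet measured. It differs from compound 2 by fluoro in place of cyano on an aromatic carbon, the same change carried out on the other core, the place being described in the same words in both cases. In this assay the expected step is no change at the digits printed from compound 2 to compound 4 (within the scatter), which rests on the earlier step of no change at the digits printed from compound 1 to compound 3 (within the scatter) having stayed within the scatter. Compound 4 is accordingly estimated at 40%, with a range from 25% to 55%.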

Compound 4, a percentage reported as inhibition, at one concentration (the size of the read-out at that concentration, not a potency): 40%
Compound 4: middle estimate and measured number agree at the digits printed, within the range that was stated.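

In this assay the step for fluoro in place of cyano on an aromatic carbon is no change at the digits printed from compound 2 to compound 4 (within the scatter), and it agrees with the step seen on the other core: the same change on two cores in this assay, no change at the digits printed (within the scatter) from compound 1 to compound 3 and no change at the digits printed (within the scatter) from compound 2 to compound 4, 0 percentage points apart, within the scatter of two such steps.
Within these two pairs, the change therefore carries from one core to the other as a step within the scatter on both. This does not show that a larger step would carry across cores, as neither pair contains one, and readings at one concentration do not give the potency of any compound.

On these data alone, it remains open whether another group at this place, such as an amine or a carboxylic acid, would move the read-out beyond the scatter on either core, and whether such a step would match between the two cores. Also open, as far as these compounds go, are which parts of the difference between the two cores matter, if any, and how these compounds would compare across a range of concentrations.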